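Swapping fluorine for iodine on a calpain inhibitor

A few compounds are considered here, and "the series" means these few. Any claim that something is new, unique, unknown or untested is made for them only; others in the source may bear on it.

Among the two compounds measured in an assay on isolated protein for inhibition of Calpain-1 catalytic subunit (Sus scrofa) (on this read-out higher numbers stand for weaker inhibition and lower numbers for stronger inhibition), compound 2 `O=C(O)/C(S)=C/c1c[nH]c2c(F)cccc12` has the lowest number: in this assay compound 2 gives 110 nM. For the measured compounds named here, the only other measured compound, compound 1 `O=C(O)/C(S)=C/c1cccc(F)c1`, gives 31500 nM in this assay, a gap far beyond the usual scatter of repeated measurements. Compound 3 `O=C(O)/C(S)=C/c1c[nH]c2c(I)cccc12` has not yet been measured. It differs from compound 2 in one place: iodo in place of fluoro on an aromatic carbon. Going by the values given here, no measured pair shows this kind of exchange of one halogen for another, so the two numbers in hand give no guide to its effect on inhibition. The expected step, a 1.2-fold lower number from compound 2 to compound 3 (0.09 log units; within the scatter), is therefore small, of no clear direction, and quite possibly within the scatter. Compound 3 is expected to give about 90 nM in this assay, with a likely range from 25 nM to 350 nM.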

Compound 3, half-maximal inhibitory concentration: 220 nM
Beside the measured number, compound 3's estimate is 2.4-fold (0.39 log units) below it; the measured number falls inside the stated range.
By their numbers in this assay, from the lowest: compounds 2 and 3 (each within the scatter of the next); then compound 1.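

Going from fluoro to iodo on this aromatic carbon, this assay shows a 2.0-fold higher number from compound 2 to compound 3 (0.30 log units; within the scatter), so on this read-out compound 2 and compound 3 cannot be told apart. This pair gives the first direct view of this position, ortho to a fused ring, and it shows that inhibition in the low range seen for compound 2 survives the exchange of one halogen for another. Nothing measured here bears on why the exchange leaves the number within the scatter.

Going by these compounds, whether this position accepts only halogens remains open, since a methoxy group, an amine or a nitrile in the same place could behave quite differently. On these data alone, it is also open whether plain hydrogen there would keep inhibition at this level, which would show whether a halogen is needed at all.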